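Adding a Cyclohexylamino Group to Compound 1

The compounds below may be only part of what the source reports. "The series", "measured", "known", "first", "only" and "open" are said of these compounds alone.

Compound 1 `N=C(Nc1cccc(C(F)(F)F)c1)c1cc2c(-c3ccccc3)n[nH]c2cn1`: 24600 nM
Compound 2 `COc1ccc(Cn2nc(-c3ccccc3)c3cc(C(=N)Nc4cccc(C(F)(F)F)c4)ncc32)cc1`: 46700 nM
Compound 3 `N=C(Nc1cccc(C(F)(F)F)c1)c1cc2cn[nH]c2cn1`: 36500 nM

All three were tested in a functional assay on HT-1080 cells (Homo sapiens) for cytotoxicity, read by MTT assay, with a stated time of 72 h; on this read-out lower numbers stand for stronger inhibition and higher numbers for weaker inhibition. Compound 1 has the lowest of the three numbers, yet neither other compound is separated from it: a 1.9-fold higher number from compound 1 to compound 2 (0.28 log units; within the scatter), and a 1.5-fold higher number from compound 1 to compound 3 (0.17 log units; within the scatter). Compound 4 `N=C(Nc1cccc(C(F)(F)F)c1)c1cc2c(-c3ccccc3)n[nH]c2c(NC2CCCCC2)n1` has not yet been measured. It differs from compound 1 by cyclohexylamino in place of hydrogen on an aromatic carbon. For the measured compounds named here, no measured step touches this place, so the two known steps bear on it only indirectly, by showing that two changes elsewhere on the shared core left this assay unmoved. The data give no ground for a step beyond the scatter in either direction. Compound 4 is therefore expected to give about 16000 nM, within 4000 nM to 60000 nM. The expected step is a 1.5-fold lower number from compound 1 to compound 4 (0.19 log units; within the scatter).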

Compound 4, half-maximal inhibitory concentration: 21200 nM
Compound 4: the middle estimate sits 1.3-fold (0.12 log units) below what was measured; low and high end bracket the measured number.
By their numbers in this assay, from the lowest: compounds 4, 1, 3 and 2 (each within the scatter of the next, the first and the last beyond it).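

On the aromatic carbon next to the ring nitrogen, cyclohexylamino replaces hydrogen with a 1.2-fold lower number from compound 1 to compound 4 (0.06 log units; within the scatter) in this assay. For the compounds shown here, this position, untouched by the earlier steps, therefore accepts a six-membered non-aromatic ring with no step beyond the scatter, as did the two changes elsewhere on the shared core. Nothing available explains this flat result.

Going by these compounds, whether a plain amine, a methoxy group or a carboxylic acid at this position would behave the same stays open. So does whether any single change here can give a step beyond the scatter.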